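A few compounds are considered here, and "the series" means these few. Any claim that something is new, unique, unknown or untested is made for them only; others in the source may bear on it.

Compound 1 `COc1ccc(CN(C(=O)CSC(=S)N2CCN(C(C)=O)CC2)c2cc(OC)c(OC)c(OC)c2)cc1`: 480 nM
Compound 2 `COc1ccc(CN(C(=O)CSC(=S)N2CCN(C(=O)OC(C)(C)C)CC2)c2cc(OC)c(OC)c(OC)c2)cc1`: 310 nM

In a functional assay on MGC-803 cells (Homo sapiens) for inhibition, read by CCK-8 assay, with a stated time of 48 h (on this read-out higher numbers stand for weaker inhibition and lower numbers for stronger inhibition), compound 2 gives 310 nM and compound 1 gives 480 nM, so the two stand within the scatter of each other. The next compound, compound 3 `COc1ccc(CN(C(=O)CSC(=S)N2CCN(Cc3ccc(C(C)(C)C)cc3)CC2)c2cc(OC)c(OC)c(OC)c2)cc1`, departs from compound 2 by a larger change: 4-(tert-butyl)benzyl in place of tert-butoxycarbonyl on an amine nitrogen in a ring. In words, 4-(tert-butyl)benzyl takes the place of tert-butoxycarbonyl on an amine nitrogen in a ring.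

For the measured compounds named here, only one measured step bears on this. That step, a 1.5-fold lower number from compound 1 to compound 2 (0.19 log units; within the scatter), put tert-butoxy in place of methyl on a carbonyl carbon, and the carbonyl stayed in both compounds. Going by the values given here, no measured compound lacks that carbonyl, so the data give no direction for its loss. Among the compounds with values here, the small size of the one step offers only weak guidance, and no shift beyond the scatter can be predicted with confidence in this assay. The expected change is a 1.1-fold higher number from compound 2 to compound 3 (0.05 log units; within the scatter), and the uncertainty around it is wide. The estimated value for compound 3 is 350 nM, with an expected range from 100 nM to 1200 nM.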

Compound 3, half-maximal inhibitory concentration: 5390 nM
Beside the measured number, compound 3's estimate is 15-fold (1.19 log units) below it; the measured number lies above the stated range.
By their numbers in this assay, from the lowest: compounds 2 and 1 (each within the scatter of the next); then compound 3.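

In this assay, the group on the amine nitrogen in a ring proves able to move the number far beyond the scatter, which the earlier step, a 1.5-fold lower number from compound 1 to compound 2 (0.19 log units; within the scatter), gave no sign of. Putting 4-(tert-butyl)benzyl on that nitrogen gives a 17-fold higher number from compound 2 to compound 3 (1.24 log units; beyond the scatter), and the same group in place of acetyl gives an 11-fold higher number from compound 1 to compound 3 (1.05 log units; beyond the scatter), so among these compounds inhibition is clearly weaker with this benzyl group than with either carbonyl-linked group. Both steps remove the carbonyl and bring in a six-membered aromatic ring at once, and nothing at hand says why the number rises so far.

The compounds shown leave open whether the loss of the carbonyl or the arrival of the aromatic ring carries the change: a benzoyl group on the same nitrogen would keep the carbonyl alongside an aromatic ring, while a plain benzyl would show what the tert-butyl adds. They also leave open how a free amine or a small alkyl group such as methyl on that nitrogen would stand against compound 2 and compound 3.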